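The source may hold more compounds than are shown below. What is called first, only, known or untested is meant among the compounds shown, and "the series" means these compounds.

Of the compounds shown here, three sharing one core have been measured. Compound 1 `CC(C)(C)Cc1c(/C=C/c2ccc(Cl)cc2)sc(N)c1C(=O)c1ccc(Cl)cc1` carries a 2-(4-chlorophenyl)ethenyl group on an aromatic carbon of that core, and in an assay on CHO cells for displacement of a labelled ligand from adenosine receptor A3 (Homo sapiens), read by scintillation counting, tested at 10 uM (on this read-out higher numbers stand for more inhibition at the one concentration tested (going by the name of the read-out) and lower numbers for less inhibition), compound 1 gives 11%. Compound 2 `Cc1ccc(-c2sc(N)c(C(=O)c3ccc(Cl)cc3)c2CC(C)(C)C)cc1` gives 1%, and compound 3 `CC(C)(C)Cc1c(-c2ccccc2)sc(N)c1C(=O)c1ccc(Cl)cc1` gives 1%. Every step among the three falls within the scatter: a number 10 percentage points lower from compound 1 to compound 2 (within the scatter), a number 10 percentage points lower from compound 1 to compound 3 (within the scatter), and no change at the digits printed from compound 2 to compound 3 (within the scatter). Compound 3 thus stands level with compound 2 at the digits shown, the two together forming the lowest of the three numbers, with compound 1 the furthest from it.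

Compound 4 `CC(C)(C)Cc1c(-c2ccccc2)sc(N)c1C(=O)c1ccc(Cl)c(Cl)c1` differs from compound 3 by chloro in place of hydrogen on an aromatic carbon. Within the data shown here, none of the measured steps involves a chloro group entering; the recorded steps concern the aromatic substituent on the other side of the core and a methyl-to-hydrogen exchange, and all of them stayed within the scatter. Nothing in these numbers points to a move beyond the scatter. Compound 4 is therefore expected near 3%, within -5% to 15%. The estimated step is a number 2 percentage points higher from compound 3 to compound 4 (within the scatter).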

Compound 4, a percentage reported as inhibition, at one concentration (the size of the read-out at that concentration, not a potency): 6%
The estimate for compound 4 lay 3 percentage points below the measured number, and the stated range covers the measured number.
By their numbers in this assay, from the lowest: compounds 2, 3, 4 and 1 (each within the scatter of the next).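

In this assay, the change from 4-chlorophenyl to 3,4-dichlorophenyl gives a number 5 percentage points higher from compound 3 to compound 4 (within the scatter), and it is the only step shown on this ring rather than on the aromatic substituent at the other position of the shared core. Chloro in place of hydrogen, on an aromatic carbon ortho to a chloro group and meta to a large group, therefore joins the earlier changes in producing no step beyond the scatter. No supporting measurement bears on this step.

The compounds shown leave open whether a methoxy group, an amine or a carboxylic acid at this same carbon would give a step beyond the scatter. They also leave open whether chloro at this carbon would give a similar step with the 2-(4-chlorophenyl)ethenyl group of compound 1 in place of phenyl.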